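Replacing the Tail on the Carbonyl Carbon of Compound 2

This account rests on a few compounds, and the source may have more. Where it says the series, first, only, none or still open, it means among the compounds named here.

In an assay on HEK293 cells for displacement of a labelled ligand from NPC1-like intracellular cholesterol transporter 1 (Homo sapiens) (a higher number here means a weaker inhibitor, a lower number a stronger inhibitor), compound 2 `CC(C)(C)OC(=O)NCCNC(=O)CN1CN(c2ccccc2)C2(CCN(C(=O)c3ccc(C(C)(C)C)cc3)CC2)C1=O` gives 10900 nM, the highest of the two numbers reported. Compound 3 `CC(C)(C)OC(=O)NCCNC(=O)CN1CN(c2ccccc2)C2(CCN(C(=O)c3ccc(C4CCCCC4)cc3)CC2)C1=O` gives 5500 nM in this assay. For the measured compounds named here, the only step between measured compounds, a 2.0-fold lower number from compound 2 to compound 3 (0.30 log units; within the scatter), lies within the scatter. Compound 1 `CC(C)(C)OC(=O)NCCCCNC(=O)CN1CN(c2ccccc2)C2(CCN(C(=O)c3ccc(C(C)(C)C)cc3)CC2)C1=O` has no result in this assay: its entry reads "not determined" (no result reported).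

Compound 4 `CC(C)(C)c1ccc(C(=O)N2CCC3(CC2)C(=O)N(CC(=O)N2CCN(S(C)(=O)=O)CC2)CN3c2ccccc2)cc1` differs from compound 2 in one place: 4-(methylsulfonyl)piperazin-1-yl in place of (2-((tert-butoxycarbonyl)amino)ethyl)amino on a carbonyl carbon. Going by the values given here, no measured step touches this part of the molecule: the one known step, between compound 2 and compound 3, is at an aromatic carbon and says nothing about the group on the carbonyl carbon. There is thus no measured ground for a step in either direction beyond the scatter, and the value of compound 2 is the only anchor. The expected step in this assay is a 1.2-fold lower number from compound 2 to compound 4 (0.08 log units; within the scatter), an estimate without a clear direction. Compound 4 is estimated at 9000 nM in this assay, within a broad range from 2500 nM to 35000 nM.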

Compound 4, half-maximal inhibitory concentration: 19000 nM
For compound 4 the middle estimate is 2.1-fold (0.32 log units) below the measured one; the measured number falls inside the stated range.
By their numbers in this assay, from the lowest: compounds 3, 2 and 4 (each within the scatter of the next, the first and the last beyond it).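

For the compounds shown here, on the carbonyl carbon, 4-(methylsulfonyl)piperazin-1-yl in place of (2-((tert-butoxycarbonyl)amino)ethyl)amino gives a 1.7-fold higher number from compound 2 to compound 4 (0.24 log units; within the scatter) in this assay, the first measured step at this position. In this one pair, exchanging an open chain with 2 hydrogen-bond donors for a six-membered ring with 0 donors leaves the number within the scatter, so the change gives no measured sign that the group on this carbon matters. No measurement shown here offers an explanation for this result.

On these data alone, it remains open whether a free primary amine at the end of the ethyl chain, a carboxylic acid or a morpholine ring on this carbonyl carbon would move the number beyond the scatter from compound 2. Also open, as far as these compounds go, is whether cyclohexyl in place of tert-butyl would give a similar step when 4-(methylsulfonyl)piperazin-1-yl is present.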